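Pyrazole-core amide series: expected value for compound 4

The source may hold more compounds than are shown below. What is called first, only, known or untested is meant among the compounds shown, and "the series" means these compounds.

Measured so far, in a functional assay on HepG2 cells (Homo sapiens) for inhibition, read by MTT assay, with a stated time of 72 h; a lower number here means a stronger inhibitor, a higher number a weaker inhibitor:
compound 1 `Cc1noc(C)c1-c1cnc(N)c(Oc2ccc(C(=O)Nc3cccc(Cl)c3)cc2)n1` gives 7300 nM
compound 2 `Cc1noc(C)c1-c1cnc(N)c(Oc2ccc(C(=O)Nc3cccc(Cl)n3)cc2)n1` gives 35700 nM
compound 3 `Cn1cc(-c2cnc(N)c(Oc3ccc(C(=O)Nc4cccc(Cl)c4)cc3)n2)cn1` gives 21200 nM

Compound 4 `Cn1cc(-c2cnc(N)c(Oc3ccc(C(=O)Nc4cccc(Cl)n4)cc3)n2)cn1` is not yet measured in this assay. It differs from compound 3 by 6-chloropyridin-2-yl in place of 3-chlorophenyl on an amide-type nitrogen. The same change has been made once before among the compounds shown, from compound 1 to compound 2, as 6-chloropyridin-2-yl in place of 3-chlorophenyl on an amide-type nitrogen; the place of the change is described in the same words in both pairs, so it is the same change on two different cores. In this assay it gave a 4.9-fold higher number from compound 1 to compound 2 (0.69 log units; beyond the scatter).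

The two cores differ as 1-methyl-1H-pyrazol-4-yl in place of 3,5-dimethyl-1,2-oxazol-4-yl on an aromatic carbon. That change on its own gave a 2.9-fold higher number from compound 1 to compound 3 (0.46 log units; beyond the scatter), so compound 3 starts from a higher number than compound 1. Compound 3 and compound 2 stand within the scatter of each other, so nothing is said here about their order.

Among the compounds with values here, for compound 4 a step of about the same size as before is expected, a 4.5-fold higher number from compound 3 to compound 4 (0.65 log units; beyond the scatter), because the only precedent, a 4.9-fold higher number from compound 1 to compound 2 (0.69 log units; beyond the scatter), was made on a core that differs only as 1-methyl-1H-pyrazol-4-yl in place of 3,5-dimethyl-1,2-oxazol-4-yl on an aromatic carbon. The expectation rests on a single pair, so it is held loosely. Compound 4 is expected to give about 95000 nM, with a range from 35000 nM to 250000 nM in this assay; a number this high may be reported only as a limit of the assay.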

Compound 4, half-maximal inhibitory concentration: 44200 nM
Estimate against measurement, compound 4: 2.1-fold (0.33 log units) above, within the range that was stated.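

In this assay, the change from 3-chlorophenyl to 6-chloropyridin-2-yl on the amide-type nitrogen again raises the number on the second core, with a 2.1-fold higher number from compound 3 to compound 4 (0.32 log units; beyond the scatter) as the new step, and the two steps point the same way and cannot be told apart in size: the same change on two cores in this assay, a 4.9-fold higher number (0.69 log units; beyond the scatter) from compound 1 to compound 2 and a 2.1-fold higher number (0.32 log units; beyond the scatter) from compound 3 to compound 4, 2.3-fold (0.37 log units) apart, within the scatter of two such steps.

The exchange of cores gives a 1.2-fold higher number from compound 2 to compound 4 (0.09 log units; within the scatter) with the 6-chloropyridin-2-yl amide in place, so compound 2 and compound 4 cannot be ordered, yet this step too cannot be told apart from its counterpart with the 3-chlorophenyl amide: the same change on two cores in this assay, a 2.9-fold higher number (0.46 log units; beyond the scatter) from compound 1 to compound 3 and a 1.2-fold higher number (0.09 log units; within the scatter) from compound 2 to compound 4, 2.3-fold (0.37 log units) apart, within the scatter of two such steps.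

The change therefore carries across these two cores in direction and, within the scatter, in size, but two pairs do not show that its size is constant or that it would hold on a further core.

Still open, as far as these compounds go, is which feature of the amide substituent governs the step, for example whether an unsubstituted phenyl or pyridin-2-yl, or a methoxy or trifluoromethyl group in place of the chlorine, would follow the same direction. Also open, from the compounds shown here alone, is whether the change behaves alike on a core bearing a saturated amine such as morpholine in place of the 1-methyl-1H-pyrazol-4-yl or 3,5-dimethyl-1,2-oxazol-4-yl group.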